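The source may hold more compounds than are shown below. What is called first, only, known or untested is meant among the compounds shown, and "the series" means these compounds.

Of the compounds shown here, two have numbers so far in a functional assay on HEp-2 cells (Homo sapiens) for cytotoxicity, read by sulforhodamine B assay, with a stated time of 48 h; a higher number here means a weaker inhibitor, a lower number a stronger inhibitor. In that assay compound 1 `CC(=O)N1N=C(c2cccc3ccccc23)CC1c1ccccc1[N+](=O)[O-]` gives 3960 nM, and compound 2 `O=CCN1N=C(c2ccc3ccccc3c2)CC1c1cccc([N+](=O)[O-])c1` gives 3870 nM. Among the compounds with values here, these two values lie within the scatter of each other, so compound 2 stands level with the only other measured compound. The next compound, compound 3 `O=CCN1N=C(c2ccc3ccccc3c2)CC1c1ccco1`, keeps the formylmethyl group of compound 2 and carries furan-2-yl in place of 3-nitrophenyl on a saturated ring carbon. Within the data shown here, no measured pair shows what such an exchange does, so the expectation is a cautious one. In this assay a small step towards a higher number is expected, one that may not clear the scatter. The expected change is a 1.4-fold higher number from compound 2 to compound 3 (0.15 log units; within the scatter). For compound 3 the estimated value is 5500 nM, with an expected range from 1800 nM to 17000 nM.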

Compound 3, half-maximal inhibitory concentration: 19000 nM
Estimate against measurement, compound 3: 3.5-fold (0.54 log units) below, outside the stated range (above it).
By their numbers in this assay, from the lowest: compounds 2 and 1 (each within the scatter of the next); then compound 3.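

In this assay, the saturated ring carbon of the shared core proves sensitive to its substituent: with the formylmethyl group kept, furan-2-yl in place of 3-nitrophenyl gives a 4.9-fold higher number from compound 2 to compound 3 (0.69 log units; beyond the scatter). Within the data shown here, this is the first single-place change, and it clears the scatter in the direction of a weaker inhibitor, though the step is modest. Nothing available here accounts for this step.

This single exchange leaves open whether the difference follows the nitro group or the change of ring, a question that a plain phenyl or a thiophen-2-yl group on the same carbon could help to separate. On these data alone, it also remains open whether the step would carry over to compounds bearing an acetyl group in place of the formylmethyl group.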